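Removing the Amide Hydrogen: From Compound 3 to Compound 4

The source may hold more compounds than are shown below. What is called first, only, known or untested is meant among the compounds shown, and "the series" means these compounds.

compound 1, `O=C(NC1CC1)c1ccc(-c2cnccc2-c2ccccc2)cc1`, 74 nM
compound 2, `O=C(NC1CC1)C1CCN(c2cncnc2-c2ccccc2)CC1`, 44 nM
compound 3, `CCNC(=O)C1CCN(c2cncnc2-c2ccccc2)CC1`, 58 nM

All three were tested in an assay on HEK293F cells for inhibition of cholesterol 24-hydroxylase (Homo sapiens), read by trypan blue exclusion, with stated times of 15 min and 5 h; a higher number here means a weaker inhibitor, a lower number a stronger inhibitor. Compound 3 gives 58 nM; compound 1 gives 74 nM and compound 2 gives 44 nM, both within the scatter of compound 3, so no order among the three can be stated. Within the data shown here, the one measured step, a 1.3-fold higher number from compound 2 to compound 3 (0.12 log units; within the scatter), changed only the group on the amide nitrogen and stayed within the scatter. Compound 4, `CN(C)C(=O)C1CCN(c2cncnc2-c2ccccc2)CC1`, differs from compound 3 by dimethylamino in place of ethylamino on a carbonyl carbon; the amide hydrogen is lost. Among the measured compounds shown here, no measured step covers such a change, so the expectation is uncertain. A modest step toward a weaker inhibitor is expected, a 1.6-fold higher number from compound 3 to compound 4 (0.19 log units; within the scatter). Compound 4 is estimated at 90 nM, likely between 30 nM and 300 nM.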

Compound 4, half-maximal inhibitory concentration: 16 nM
Beside the measured number, compound 4's estimate is 5.6-fold (0.75 log units) above it, and the stated range ends above it.
By their numbers in this assay, from the lowest: compound 4; then compounds 2, 3 and 1 (each within the scatter of the next).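

At this carbonyl carbon, the amide group can shift the number beyond the scatter: in this assay, dimethylamino in place of ethylamino gives a 3.6-fold lower number from compound 3 to compound 4 (0.56 log units; beyond the scatter). The same holds against cyclopropylamino, with a 2.8-fold lower number from compound 2 to compound 4 (0.44 log units; beyond the scatter), whereas ethyl and cyclopropyl on the amide nitrogen differed only within the scatter. Here, the two amides that keep the amide hydrogen both give higher numbers than the one that lacks it, but nothing measured here explains that difference. On these data alone, whether the lower number depends on losing that hydrogen stays open. Diethylamino or a pyrrolidine amide, which also lack it, would test this, as would methylamino, which keeps it.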